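Carboxy to ethylcarbamoyl: the amide still to be measured

The source may hold more compounds than are shown below. What is called first, only, known or untested is meant among the compounds shown, and "the series" means these compounds.

Compound 2 `COc1ccc(Cl)cc1S(=O)(=O)Nc1cncc(C(=O)O)c1` returns only a limit in an assay on isolated protein for inhibition of alkaline phosphatase, tissue-nonspecific isozyme (Homo sapiens); on this read-out lower numbers stand for stronger inhibition and higher numbers for weaker inhibition; compound 2 sits at > 20000 nM. Compound 1 `COc1ccc(Cl)cc1S(=O)(=O)Nc1cncc(-c2ccncc2)c1` likewise returns a limit, and in this assay compound 1 shows > 20000 nM. The step between them, a step that the two limits leave unreadable from compound 1 to compound 2, cannot be read, since (the limit of > 20000 nM in this assay, at which 2 of the 2 values shown sit). Compound 3 `CCNC(=O)c1cncc(NS(=O)(=O)c2cc(Cl)ccc2OC)c1` differs from compound 2 by ethylamino in place of hydroxy on a carbonyl carbon. Among the compounds with values here, no measured step touches the carbonyl substituent in a readable way; the single step recorded, from compound 1 to compound 2, is hidden by the two limits, so no direction or size can be drawn from it. Compound 2 itself stands at the limit, so any gain by compound 3 would have to be large before a number appears at all. The expectation for compound 3 in this assay is therefore a value at or beyond the limit, that is an expected step that the limit leaves unreadable from compound 2 to compound 3 that cannot be told from none. Compound 3 is estimated at 30000 nM, with a range from 8000 nM to 150000 nM, and will most likely be reported only as a limit.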

Compound 3, half-maximal inhibitory concentration: > 20000 nM
Compound 3 was reported as a limit; the forecaster's own chance of this, stated with the estimate: 75%; the middle value is on the limit's open side.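

No new step can be read for compound 3 against compound 1 or compound 2 in this assay since all three remain limits: the limit of > 20000 nM in this assay, at which 3 of the 3 values shown sit. The compounds shown leave open how pyridin-4-yl, carboxy and ethylcarbamoyl rank against one another, and whether any group in that place on the shared core gives a measurable value.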